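A few compounds are considered here, and "the series" means these few. Any claim that something is new, unique, unknown or untested is made for them only; others in the source may bear on it.

Among the measured compounds shown here, compound 1 `CC(C)c1cc(C(=O)N2CCc3c(sc(NCc4ccccc4)c3C#N)C2)[nH]n1` is the starting point of this short series, and in a functional assay on Chem-3 cells for antagonist activity at metabotropic glutamate receptor 1 (Homo sapiens), read by fluorescence and calcium flux (on this read-out lower numbers stand for stronger inhibition and higher numbers for weaker inhibition), compound 1 gives 43200 nM, which makes it a weak antagonist in this assay; it is also the only compound here with a number attached. Compound 2 `CC(C)c1cc(C(=O)N2CCc3c(sc(NCc4ccc(F)cc4)c3C#N)C2)[nH]n1` and compound 3 `CC(C)c1cc(C(=O)N2CCc3c(sc(NCc4ccc(Cl)cc4)c3C#N)C2)[nH]n1` belong to the same family, but for both of them this assay returned no result: compound 2 gives "not determined" (no result reported) and compound 3 gives "not determined" (no result reported), so nothing can be said about how they compare with compound 1.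

Compound 4 `N#Cc1c(NCc2ccccc2)sc2c1CCN(C(=O)c1cccc(F)c1)C2` has not been measured yet. It differs from compound 1 in one place: 3-fluorophenyl in place of 3-isopropyl-1H-pyrazol-5-yl on a carbonyl carbon. The amide-type nitrogen in the ring and the rest of the shared core stay the same. For the measured compounds named here, since no pair of measured compounds shows the effect of such a swap, the size and direction of the step can only be guessed; a moderate gain in potency is expected, with the change from compound 1 to compound 4 estimated at a 2.9-fold lower number from compound 1 to compound 4 (0.46 log units; beyond the scatter). On that basis compound 4 is expected to give about 15000 nM in this assay, most likely between 3000 nM and 60000 nM.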

Compound 4, half-maximal inhibitory concentration: 2900 nM
Estimate against measurement, compound 4: 5.2-fold (0.71 log units) above, outside the stated range (below it).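

The group on the carbonyl carbon has a large influence on activity: in this assay putting 3-fluorophenyl in place of 3-isopropyl-1H-pyrazol-5-yl gives a 15-fold lower number from compound 1 to compound 4 (1.17 log units; beyond the scatter) while the rest of the molecule stays the same. The 3-isopropyl-1H-pyrazol-5-yl group has a hydrogen-bond donor and a hydrogen-bond acceptor, whereas 3-fluorophenyl has neither, so activity at this place does not depend on keeping that donor and acceptor. No measurement available here explains why this swap gives the gain.

From the compounds shown here alone, it remains open whether the gain comes from the fluorine or from the carbon-only aromatic ring, a question that a plain phenyl group on the same carbonyl carbon could help settle. How a pyridyl ring, or a group carrying an amine or a carboxylic acid, would behave at this place is also unknown.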